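The compounds below may be only part of what the source reports. "The series", "measured", "known", "first", "only" and "open" are said of these compounds alone.

Values in a functional assay on HL-60 cells (Homo sapiens) for inhibition, read by resazurin assay, with a stated time of 72 h; on this read-out higher numbers stand for weaker inhibition and lower numbers for stronger inhibition:
- compound 1 `CCSc1ccc(C2CC(=O)N2c2cc(OC)c(OC)c(OC)c2)cc1`: 204 nM
- compound 2 `C=CC1C(=O)N(c2cc(OC)c(OC)c(OC)c2)C1c1ccc(SCC)cc1`: 320 nM

Going by the values given here, compound 2 stands within the scatter of compound 1, and the only measured step is a 1.6-fold higher number from compound 1 to compound 2 (0.20 log units; within the scatter). Among the compounds with values here, that step concerns vinyl in place of hydrogen on a saturated ring carbon, so no measured step covers the next change. Compound 3 `C=CC1C(=O)N(c2cc(OC)c(OC)c(OC)c2)C1c1ccc(OCC)cc1` has ethoxy in place of ethylsulfanyl on an aromatic carbon, para to a large group (ethoxy in place of ethylsulfanyl on an aromatic carbon). The expectation therefore starts from compound 2 at 320 nM, with no step beyond the scatter expected in this assay. The expected step is a 1.3-fold lower number from compound 2 to compound 3 (0.11 log units; within the scatter). For compound 3 the estimated value is 250 nM, with an expected range of 80 nM to 800 nM.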

Compound 3, half-maximal inhibitory concentration: 35 nM
For compound 3 the middle estimate is 7.1-fold (0.85 log units) above the measured one, and the stated range ends above it.
By their numbers in this assay, from the lowest: compound 3; then compounds 1 and 2 (each within the scatter of the next).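

In this assay, the aromatic carbon para to a large group proves sensitive to the atom linking the ethyl chain: a 9.1-fold lower number from compound 2 to compound 3 (0.96 log units; beyond the scatter). The two groups match in the counts computed for them and differ only in oxygen for sulfur, yet this step exceeds the scatter, unlike the vinyl step. No available evidence bears on the reason for the step.

Open, going by these compounds, is whether ethoxy gives a similar step on the core of compound 1, without vinyl. Also open, on these data alone, is whether a longer chain such as propoxy, or an amine, at this position would match compound 3 at 35 nM.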